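The source may hold more compounds than are shown below. What is called first, only, known or untested is meant among the compounds shown, and "the series" means these compounds.

In an ADME assay on Vero cells (Chlorocebus sabaeus) for cytotoxicity, read by MTT assay, with a stated time of 72 h (a higher number here means that more compound is tolerated, a lower number that less compound is tolerated), compound 1 `NS(=O)(=O)c1ccc(N2N=C(c3ccc(Cl)cc3Cl)CC2c2cn(-c3ccccc3)nc2-c2ccccc2)cc1` gives > 437000 nM, which is a limit. Compound 2 `NS(=O)(=O)c1ccc(N2N=C(c3ccc(Cl)cc3)CC2c2cn(-c3ccccc3)nc2-c2ccccc2)cc1` gives > 206000 nM, also a limit. Compound 3 `NS(=O)(=O)c1ccc(N2N=C(c3ccc(O)cc3)CC2c2cn(-c3ccccc3)nc2-c2ccccc2)cc1` gives > 160000 nM, again a limit. Compound 2 therefore stands, like the other two, on a limit and not on a number. Compound 4 `COc1ccc(C2=NN(c3ccc(S(N)(=O)=O)cc3)C(c3cn(-c4ccccc4)nc3-c3ccccc3)C2)cc1` differs from compound 2 by methoxy in place of chloro on an aromatic carbon, with methoxy in place of chloro on an aromatic carbon. The nearest measured change is a step that the two limits leave unreadable from compound 2 to compound 3. The other two are a step that the two limits leave unreadable from compound 1 to compound 2 and a step that the two limits leave unreadable from compound 1 to compound 3. None of them gives a size or a direction to carry over, so no shift beyond the scatter is expected in this assay. The expected change is a step that the limit leaves unreadable from compound 2 to compound 4. For compound 4 the estimate is 220000 nM, with an expected range from 100000 nM to 500000 nM.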

Compound 4, half-maximal cytotoxic concentration: 40200 nM
Beside the measured number, compound 4's estimate is 5.5-fold (0.74 log units) above it, and the stated range ends above it.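

In this assay, compound 4 is the first of these compounds to give a number and not a limit, and the earlier steps, which cannot be read, now gain a direction at this position: an at least 5.1-fold lower number from compound 2 to compound 4 (0.70 log units; beyond the scatter), an at least 3.9-fold lower number from compound 3 to compound 4 (0.59 log units; beyond the scatter) and an at least 10-fold lower number from compound 1 to compound 4 (1.03 log units; beyond the scatter). On the shared core, 4-methoxyphenyl is thus tolerated less well than 4-chlorophenyl, 4-hydroxyphenyl or 2,4-dichlorophenyl. Nothing given here accounts for this drop. From the compounds shown here alone, what an ethoxy group or an amine would give in this place on the ring stays open. Going by these compounds, the full size of each step also stays open, as each one ends on a limit.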